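Swapping trifluoromethyl for fluoro on a triazine fatty acid receptor agonist

A few compounds are considered here, and "the series" means these few. Any claim that something is new, unique, unknown or untested is made for them only; others in the source may bear on it.

The measured compounds and their values:
- compound 1, `Cc1ccc(Nc2nc(N)nc(COc3ccc4c(C)cc(=O)oc4c3)n2)cc1C`: 210 nM
- compound 2, `Cc1ccc(Nc2nc(N)nc(COc3cccc(N4CCCC4=O)c3)n2)cc1Cl`: 820 nM
- compound 3, `Cc1ccc(Nc2nc(N)nc(COc3cc(N4CCCC4=O)cc(C(F)(F)F)c3)n2)cc1Cl`: 3190 nM

In an assay on COS-7 cells for agonist activity at Free fatty acid receptor 1 (Homo sapiens), read by scintillation counting and inositol phosphate accumulation, with a stated time of 90 min (on this read-out higher numbers stand for an effect only at larger amounts of compound and lower numbers for an effect already at smaller amounts), compound 3 gives the highest number of the three. Compound 2 stands nearest to it, and compound 1, with 210 nM, lies furthest away. Within the data shown here, the one step that reaches compound 3 is a 3.9-fold higher number from compound 2 to compound 3 (0.59 log units; beyond the scatter), a modest shift beyond the scatter.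

Compound 4, `Cc1ccc(Nc2nc(N)nc(COc3cc(F)cc(N4CCCC4=O)c3)n2)cc1Cl`, has not yet been measured in this assay. It differs from compound 3 in one place: fluoro in place of trifluoromethyl on an aromatic carbon. Among the measured compounds shown here, no measured pair shows this exact change. For the measured compounds named here, the only step that bears on it is a 3.9-fold higher number from compound 2 to compound 3 (0.59 log units; beyond the scatter), where a hydrogen at that carbon was replaced by trifluoromethyl and the number rose. A single fluorine sits between those two cases, so compound 4 is expected to land between compound 2 and compound 3, a step of a 2.3-fold lower number from compound 3 to compound 4 (0.36 log units; beyond the scatter) downward from compound 3. The estimate for compound 4 is 1400 nM, within a range from 600 nM to 3500 nM.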

Compound 4, half-maximal effective concentration: 1800 nM
The estimate for compound 4 lay 1.3-fold (0.11 log units) below the measured number; low and high end bracket the measured number.
By their numbers in this assay, from the lowest: compound 1; then compound 2; then compounds 4 and 3 (each within the scatter of the next).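

In this assay, replacing trifluoromethyl with fluoro gives a 1.8-fold lower number from compound 3 to compound 4 (0.25 log units; within the scatter), so the two groups cannot be told apart at this aromatic carbon, meta to a 2-oxopyrrolidin-1-yl group. The earlier compounds shown here showed only trifluoromethyl at this carbon; fluoro in place of hydrogen now gives a 2.2-fold higher number from compound 2 to compound 4 (0.34 log units; beyond the scatter), so the rise over hydrogen is not confined to trifluoromethyl. Nothing available explains why the two groups give values within the scatter of each other. Still open, going by these compounds, is whether any group at this carbon, such as an amine, a hydroxyl or a carboxylic acid, would give a lower number than hydrogen does. Also open, on these data alone, is whether fluoro would have the same effect if another group took the place of the 2-oxopyrrolidin-1-yl group.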